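This account rests on a few compounds, and the source may have more. Where it says the series, first, only, none or still open, it means among the compounds named here.

Measured compounds: compound 1 `Cn1ccc2c(Oc3ccc(NC(=O)c4nn(-c5ccccc5)ccc4=O)cc3)ccnc21`, 51700 nM; compound 2 `Cn1ccc2c(Oc3ccc(NC(=O)c4nn(-c5ccc(Br)cc5F)ccc4=O)cc3)ccnc21`, 35700 nM; compound 3 `Cn1ccc2c(Oc3ccc(NC(=O)c4nn(-c5ccc(Cl)c(F)c5)ccc4=O)cc3)ccnc21`, > 60000 nM.

In a functional assay on A549 cells (Homo sapiens) for cytotoxicity, read by MTT assay, with a stated time of 72 h (on this read-out higher numbers stand for weaker inhibition and lower numbers for stronger inhibition), compound 1 gives 51700 nM and compound 2 gives 35700 nM, a 1.4-fold lower number from compound 1 to compound 2 (0.16 log units; within the scatter). For compound 3 the assay reports only a limit, > 60000 nM. The two steps leading to it are an at least 1.1-fold higher number from compound 1 to compound 3 (0.06 log units; that floor lies within the scatter) and an at least 1.6-fold higher number from compound 2 to compound 3 (0.22 log units; that floor lies within the scatter), both within the scatter. Compound 4 `Cn1ccc2c(Oc3ccc(NC(=O)c4nn(-c5ccc(Cl)c(F)c5)ccc4=O)cc3F)ccnc21` differs from compound 3 by fluoro in place of hydrogen on an aromatic carbon. Within the data shown here, none of the measured steps touches this ring; all three vary the group on the aromatic nitrogen and stay within the scatter, with the series sitting near the limit (the limit of > 60000 nM in this assay, at which 1 of the 3 values shown sits). No step beyond the scatter is therefore expected in this assay, and a limit rather than a number is likely. Compound 4 is expected at 60000 nM, range 30000 nM to 120000 nM. The expected step is a number no higher from compound 3 to compound 4 (the limit leaves the size open).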

Compound 4, half-maximal inhibitory concentration: > 60000 nM
Compound 4: only a limit was reported; the forecaster's own chance of this, stated with the estimate: 60%; the middle value lies on the limit itself.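

Compound 4 reads > 60000 nM in this assay, a limit. Compound 3 reads > 60000 nM, also a limit, and the step between the two cannot be read. The compounds shown leave open whether fluoro in place of hydrogen on an aromatic carbon changes this read-out at all.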